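The source may hold more compounds than are shown below. What is called first, only, known or untested is meant among the compounds shown, and "the series" means these compounds.

Measured compounds:
Compound 1, `O=[N+]([O-])c1ccc(-c2nnc(C3CCc4cc(F)ccc4O3)o2)cc1`, gives 28700 nM in a functional assay; a lower number here means a stronger inhibitor, a higher number a weaker inhibitor.
Compound 2, `COc1cc(-c2nnc(C3CCc4cc(F)ccc4O3)o2)cc(OC)c1OC`, gives 43200 nM in this assay.

Both numbers point to weak inhibition. Compound 1 has the lower of the two, but its gap to compound 2 lies within the usual scatter, so neither compound can be called the stronger inhibitor on these data. Compound 3, `Fc1ccc2c(c1)CCC(c1nnc(-c3ccccc3)o1)O2`, has not yet been measured in this assay. It differs from compound 1 in one place: hydrogen in place of nitro on an aromatic carbon. Going by the values given here, no two measured compounds differ by a single change, so there is no measured step that shows what such a change does in this assay; the two measured values only show that two rather different groups both give weak inhibition. The expected step of a 1.4-fold higher number from compound 1 to compound 3 (0.14 log units; within the scatter) is small, no larger than the scatter, and if anything toward a weaker inhibitor. For compound 3 the estimate in this assay is 40000 nM, with a range from 12000 nM to 130000 nM.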

Compound 3, half-maximal inhibitory concentration: 28700 nM
Estimate against measurement, compound 3: 1.4-fold (0.14 log units) above, and the stated range covers the measured number.
By their numbers in this assay, from the lowest: compounds 1, 3 and 2 (each within the scatter of the next).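

Going by these compounds alone, the step from the nitro compound to the unsubstituted one is the first direct comparison at this position: in this assay, hydrogen in place of nitro on this aromatic carbon, para to a large group, shows no change at the digits printed from compound 1 to compound 3 (within the scatter). The nitro group is therefore not needed for the weak inhibition seen in compound 1, since the compound without it remains a weak inhibitor. No other measurement shown here offers an explanation for this result.

On these data alone, whether an amine or a carboxylic acid on this same carbon would give a number beyond the scatter from compound 3 stays open. As far as these compounds go, all three compounds also share one core, so what a change to that core would do in this assay remains unknown.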